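Swapping the para substituent on the pendant phenyl ring

The source may report more compounds than this note shows. Statements on the series, on what has been measured and on what is new or still open speak of the compounds shown alone.

Measured so far:
compound 1 `COc1ccc(-c2cc3nccc(-c4cc(OC)c(OC)c(OC)c4)n3n2)cc1F` 545 nM
compound 2 `COc1cc(-c2ccnc3cc(-c4c[nH]c5ccccc45)nn23)cc(OC)c1OC` 29 nM
compound 3 `COc1cc(-c2ccnc3cc(-c4ccc(C(F)(F)F)cc4)nn23)cc(OC)c1OC` 2070 nM

These three compounds share one core and differ only in the aromatic group attached to it. In a functional assay on A549 cells (Homo sapiens) for inhibition, read by CCK-8 assay, with a stated time of 48 h (a higher number here means a weaker inhibitor, a lower number a stronger inhibitor), compound 3 gives the highest number of the three: it sits a 3.8-fold higher number from compound 1 to compound 3 (0.58 log units; beyond the scatter) and a 71-fold higher number from compound 2 to compound 3 (1.85 log units; beyond the scatter). Compound 4 `C=Cc1ccc(-c2cc3nccc(-c4cc(OC)c(OC)c(OC)c4)n3n2)cc1` keeps the phenyl ring of compound 3 and changes only the group on it: vinyl in place of trifluoromethyl on an aromatic carbon. Within the data shown here, no measured step exchanges one small group on that ring for another; the steps seen, a 19-fold lower number from compound 1 to compound 2 (1.27 log units; beyond the scatter) and a 3.8-fold higher number from compound 1 to compound 3 (0.58 log units; beyond the scatter), each replace the whole aromatic group, so they set only the range within which such changes have fallen here. On that basis a modest shift is expected, and its direction cannot be read from the data. Compound 4 is estimated at 1200 nM in this assay, with a range of 350 nM to 4000 nM, which would mean a 1.7-fold lower number from compound 3 to compound 4 (0.24 log units; within the scatter).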

Compound 4, half-maximal inhibitory concentration: 1030 nM
Compound 4: the middle estimate sits 1.2-fold (0.07 log units) above what was measured, and the stated range covers the measured number.
By their numbers in this assay, from the lowest: compound 2; then compounds 1, 4 and 3 (each within the scatter of the next, the first and the last beyond it).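

In this assay, among these compounds, this is the first exchange of one small group for another on the phenyl ring, and the step (a 2.0-fold lower number from compound 3 to compound 4 (0.30 log units; within the scatter)) lies within the scatter, so vinyl and trifluoromethyl cannot be told apart at this place. Compound 4 also cannot be told apart from its 3-fluoro-4-methoxyphenyl relative (a 1.9-fold higher number from compound 1 to compound 4 (0.28 log units; within the scatter)), whereas the 1H-indol-3-yl group stays far ahead of 4-vinylphenyl (a 36-fold higher number from compound 2 to compound 4 (1.55 log units; beyond the scatter)), so the largest differences seen so far come from replacing the whole aromatic group. Nothing available explains these differences.

From the compounds shown here alone, it remains open whether any group at this place, such as an amine, a carboxylic acid or a longer chain, can move the number beyond the scatter. Going by these compounds, it is also open which part of the 1H-indol-3-yl group goes with its low number.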